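From (2-methoxyethyl)amino to Methyl on the Sulfonyl Sulfur

The source may hold more compounds than are shown below. What is called first, only, known or untested is meant among the compounds shown, and "the series" means these compounds.

In an ADME assay on a cell-free system (plasma, Rattus norvegicus) (on this read-out lower numbers stand for a smaller free fraction and higher numbers for a larger free fraction), compound 1 (`CN(C)S(=O)(=O)c1ccc(F)c(C#Cc2cc(Cl)ccc2OCC(=O)O)c1`) gives 0.007 as the lower of the two available numbers, and compound 2 (`CN(C)S(=O)(=O)c1cncc(C#Cc2cc(Cl)ccc2OCC(=O)O)c1`) gives 0.057 as the higher. Compound 3 (`COCCNS(=O)(=O)c1ccc(C)c(C#Cc2cc(Cl)ccc2OCC(=O)O)c1`) has no single number to stand on, since its result in this assay reads "not determined" (no result reported) and leaves its position open. Compound 4 (`Cc1ccc(S(C)(=O)=O)cc1C#Cc1cc(Cl)ccc1OCC(=O)O`) comes from compound 3 by a single structural change, methyl in place of (2-methoxyethyl)amino on a sulfonyl sulfur. With no starting value for compound 3, no size or direction of step can be expected from this change, and none is claimed. Among the compounds with values here, the expectation rests instead on compound 1 at 0.007 and compound 2 at 0.057 as the only measured values, with the lower part of that span favoured as a cautious judgement. For compound 4 the expected unbound fraction is 0.015 with an estimated range from 0.005 to 0.05 in this measurement.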

Compound 4, unbound fraction: 0.014
Compound 4: middle estimate off by 1.1-fold (0.03 log units), on the high side, and the stated range covers the measured number.
By their numbers in this assay, from the lowest: compounds 1 and 4 (each within the scatter of the next); then compound 2.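

Compound 3 holds no number in this assay, and the step from it to compound 4, at 0.014, cannot be read. The compounds shown leave open how methyl in place of (2-methoxyethyl)amino on a sulfonyl sulfur shifts the unbound fraction. Nothing shown offers an explanation for the value of compound 4.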